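The compounds below may be only part of what the source reports. "The series", "measured", "known", "first", "only" and "open" are said of these compounds alone.

Compound 3 `C/C(=C\c1nc(-c2ccccc2)cs1)C(N)=O` was tested in an ADME assay on NIH3T3 cells (Mus musculus) for cytotoxicity, read by CCK-8 assay, with a stated time of 24 h; a higher number here means a weaker inhibitor, a lower number a stronger inhibitor. In this assay compound 3 reaches only a limit of the assay, > 50000 nM, and no number. Compound 2 `C/C(=C\c1cc(-c2ccc(F)cc2)cs1)C(N)=O` likewise reaches only a limit, > 50000 nM. Compound 1 `C/C(=C\c1cc(C2=CCCC2)co1)C(N)=O` gives 49300 nM in this assay. Two of the three values shown thus sit at the limit of > 50000 nM in this assay, at which 2 of the 3 values shown sit. Compound 4 `C/C(=C\c1nc(-c2ccc(F)cc2)cs1)C(N)=O` differs from compound 3 by fluoro in place of hydrogen on an aromatic carbon. No step between measured compounds is shown; compound 2 carries the same fluoro and sits at a limit. The expected step of a number no higher from compound 3 to compound 4 (the limit leaves the size open) is none beyond the scatter. Compound 4 is therefore estimated at 50000 nM, with a range from 30000 nM to 80000 nM, and most likely again only a limit.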

Compound 4, half-maximal inhibitory concentration: > 50000 nM
Compound 4 gave a limit, no number; the forecaster's own chance of this, stated with the estimate: 75%; the middle value lies on the limit itself.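

Within the data shown here, compound 3 and compound 4 both reach only a limit of the assay, so no step between them can be read. The compounds shown leave open where their true values lie and whether fluoro in place of hydrogen changes anything.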